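A few compounds are considered here, and "the series" means these few. Any claim that something is new, unique, unknown or untested is made for them only; others in the source may bear on it.

The measured compounds:

Compound 1, `N[C@]1(C(=O)O)[C@H]2[C@@H](C[C@H]1OCc1ccccc1Cl)[C@]2(F)C(=O)O`: in an assay on CHO cells for binding affinity to metabotropic glutamate receptor 2 (Rattus norvegicus) (on this read-out higher numbers stand for weaker inhibition and lower numbers for stronger inhibition), compound 1 gives 4.99 nM.
Compound 2, `N#Cc1cccc(CO[C@@H]2C[C@@H]3[C@H]([C@]2(N)C(=O)O)[C@@]3(F)C(=O)O)c1`: in this assay compound 2 gives 2.94 nM.

Compound 2 stands alongside compound 1 rather than apart from it: the only gap between them is a 1.7-fold lower number from compound 1 to compound 2 (0.23 log units; within the scatter), which lies within the scatter of repeated measurements, so the two cannot be told apart on these numbers.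

The unmeasured compound 3, `Nc1cccc(CO[C@@H]2C[C@@H]3[C@H]([C@]2(N)C(=O)O)[C@@]3(F)C(=O)O)c1`, differs from compound 2 in one place: amino in place of cyano on an aromatic carbon. For the measured compounds named here, no measured step touches the cyano group itself. Going by the values given here, the single step available, a 1.7-fold lower number from compound 1 to compound 2 (0.23 log units; within the scatter), concerns the exchange of one aryl group for another and was small; it says little about a substituent swap on the same aromatic ring. With nothing in the data pointing in either direction, the step is expected to be modest, a 1.4-fold higher number from compound 2 to compound 3 (0.13 log units; within the scatter), and the uncertainty around it is wide. Compound 3 is therefore estimated at 4 nM in this assay, with an expected range from 1.5 nM to 12 nM.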

Compound 3, inhibition constant: 15.4 nM
The estimate for compound 3 lay 3.9-fold (0.59 log units) below the measured number, outside the stated range (above it).
By their numbers in this assay, from the lowest: compounds 2 and 1 (each within the scatter of the next); then compound 3.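

For the compounds shown here, the cyano group on this aromatic carbon, meta to a large group, turns out not to be interchangeable with amino: in this assay, the change gives a 5.2-fold higher number from compound 2 to compound 3 (0.72 log units; beyond the scatter), the first step beyond the scatter. The earlier pair had shown only that the 2-chlorophenyl and 3-cyanophenyl groups could not be told apart, whereas the 3-aminophenyl group separates from 2-chlorophenyl as well (a 3.1-fold higher number from compound 1 to compound 3 (0.49 log units; beyond the scatter)), leaving compound 3 as the weakest of the three on this read-out. Nothing measured here explains why the amino group gives the higher number.

The compounds shown leave open whether this step follows from the presence of the amino group or from the loss of the cyano group, a question that a hydroxyl or methyl group on the same aromatic carbon could help settle. They also leave open whether an acetamide, which would keep the nitrogen on that carbon while carrying a carbonyl, would stay near compound 3 or return towards compound 2.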